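Ethyl for 4-fluorophenyl at the limit of the assay

The compounds below may be only part of what the source reports. "The series", "measured", "known", "first", "only" and "open" are said of these compounds alone.

Compound 1 (`O=c1oc2ccccc2c(N2CCN(C(c3ccccc3)c3ccc(Cl)cc3)CC2)c1CO`) gives only a limit in a toxicity assay on HEK-293T cells (Homo sapiens) for inhibition, read by MTT assay, with a stated time of 24 h; on this read-out lower numbers stand for higher toxicity in this test and higher numbers for lower toxicity in this test (> 50000 nM). Compound 2 (`O=c1oc2ccccc2c(N2CCN(c3ccc(F)cc3)CC2)c1CO`) also stands at a limit and has no number (> 50000 nM). The two compounds thus share one limit (the limit of > 50000 nM in this assay, at which 2 of the 2 values shown sit). Compound 3 (`CCN1CCN(c2c(CO)c(=O)oc3ccccc23)CC1`) carries ethyl in place of 4-fluorophenyl on an amine nitrogen in a ring. In this assay no step beyond the scatter is expected, in either direction (a number no higher from compound 2 to compound 3 (the limit leaves the size open)). The estimated value for compound 3 is 50000 nM, with an expected range from 30000 nM to 100000 nM.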

Compound 3, half-maximal cytotoxic concentration: > 50000 nM
Compound 3 was reported as a limit; the forecaster's own chance of this, stated with the estimate: 85%; the middle value sits exactly at the limit.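

Compound 3 stands at a limit, as does compound 2, so no step can be read for ethyl in place of 4-fluorophenyl: the limit of > 50000 nM in this assay, at which 3 of the 3 values shown sit.

The compounds shown leave open whether any group on that amine nitrogen would bring a number within the range of this assay.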